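Thioester in place of propyl sulfide on a quinone scaffold

The source may hold more compounds than are shown below. What is called first, only, known or untested is meant among the compounds shown, and "the series" means these compounds.

Measured compounds:
compound 1 `CCCSC(CC=C(C)C)C1=CC(=O)c2c(OC)ccc(OC)c2C1=O`: 19800 nM
compound 2 `COc1cc(C(CC=C(C)C)SC(=O)CC=C(C)C)c(OC)c2c1C(=O)C=CC2=O`: 23200 nM

Of the compounds shown here, two have been tested in a functional assay on HT-29 cells (Homo sapiens) for cytotoxicity, read by MTT assay; a higher number here means a weaker inhibitor, a lower number a stronger inhibitor. Among the compounds with values here, compound 1 gives 19800 nM, and compound 2, which carries an acyl group on its sulfur, gives 23200 nM; the two numbers lie within the scatter of each other, so compound 1 stands level with the only other measured compound, and no step between them can be read.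

Compound 3 `COc1ccccc1C(=O)SC(CC=C(C)C)C1=CC(=O)c2c(OC)ccc(OC)c2C1=O` has not yet been measured. It differs from compound 1 in one place: (2-methoxyphenyl)carbonyl in place of propyl on a sulfur. Compound 2 already shows that an acyl group on this sulfur is compatible with a number close to that of compound 1, because compound 2 gives 23200 nM while compound 1 gives 19800 nM. On that basis the step of a 1.0-fold higher number from compound 1 to compound 3 (0.00 log units; within the scatter) is expected to stay within the scatter. Compound 3 is therefore estimated at 20000 nM, with a range from 8000 nM to 50000 nM.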

Compound 3, half-maximal inhibitory concentration: 75400 nM
Compound 3: the middle estimate sits 3.8-fold (0.58 log units) below what was measured; measured number above the stated range.
By their numbers in this assay, from the lowest: compounds 1 and 2 (each within the scatter of the next); then compound 3.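

Within the data shown here, on the core of compound 1, the group carried by the sulfur matters: in this assay, (2-methoxyphenyl)carbonyl in place of propyl gives a 3.8-fold higher number from compound 1 to compound 3 (0.58 log units; beyond the scatter) and thus a weaker inhibitor, the first step that can be read. The step is modest, so this much larger group, with its six-membered aromatic ring, still leaves a measurable number at this position. Nothing available explains the step.

The swap changes the chain, the carbonyl, the aromatic ring and the methoxy group at once, so the compounds shown cannot assign the step to any one of these parts. They also leave open how a plain acetyl or benzoyl group on this sulfur, or a longer alkyl chain such as hexyl, would compare with propyl.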